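Chloro in place of methyl on the shared core

A few compounds are considered here, and "the series" means these few. Any claim that something is new, unique, unknown or untested is made for them only; others in the source may bear on it.

- compound 1 `NC(=O)c1cnc2c(c1)CCN2` gives 223%
- compound 2 `Cc1c(C(N)=O)cnc2c1CCN2` gives 191%

Both numbers come from an ADME assay on the whole organism (Mus musculus, strain C57BL6/N) for pharmacokinetics, read by LC-MS, with a stated time of 24 h, at a dose of 50 mg/kg by the oral route; a lower number here means that a smaller share of the oral dose reaches the circulation, a higher number that a larger share of the oral dose reaches the circulation. Of the two, compound 2 stands lower, at 191%. Compound 3 `NC(=O)c1cnc2c(c1Cl)CCN2` carries chloro in place of methyl on an aromatic carbon. Among the compounds with values here, the only measured step at this carbon is a number 32 percentage points lower from compound 1 to compound 2 (beyond the scatter), a large one made by methyl in place of hydrogen. Within the data shown here, no chloro compound has been measured yet, and the group that leaves and the group that enters count the same number of heavy atoms. No step beyond the scatter is expected in this assay, and the expected step is a number 4 percentage points higher from compound 2 to compound 3 (within the scatter). Compound 3 is estimated at 195%, with an expected range from 150% to 240%.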

Compound 3, oral bioavailability: 90%
For compound 3 the middle estimate is 105 percentage points above the measured one, outside the stated range (below it).
By their numbers in this assay, from the lowest: compound 3; then compound 2; then compound 1.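

The same carbon proves far more sensitive than the methyl step suggested: in this assay, exchanging methyl for chloro, each a single heavy atom, gives a number 101 percentage points lower from compound 2 to compound 3 (beyond the scatter). Chloro in place of hydrogen gives a number 133 percentage points lower from compound 1 to compound 3 (beyond the scatter), so two single-atom groups at this carbon lower the number to clearly different extents. Nothing available explains why the two groups differ so much. The compounds shown leave open how an amine or a methoxy group at this carbon would read, and whether other halogens such as fluoro or bromo would follow chloro.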